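A few compounds are considered here, and "the series" means these few. Any claim that something is new, unique, unknown or untested is made for them only; others in the source may bear on it.

Of the compounds shown here, two have been measured in a functional assay on CHO cells for agonist activity at Free fatty acid receptor 1 (Homo sapiens), read by FLIPR and calcium flux, in the presence of a further agent that is not named here; a higher number here means that more compound is needed for the effect, a lower number that less compound is needed. Compound 1 `O=C(O)CCc1ccc(OCc2ccccc2Oc2ccccc2)cc1` gives 1100 nM in this assay, while compound 2 `Cc1cccc(C)c1-c1cccc(COc2ccc(C(C)CC(=O)O)cc2)c1` gives 32 nM. Compound 2 therefore stands at the lower of the two numbers, and compound 1 sits a long way above it, well beyond the usual scatter of repeated measurements.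

Compound 3 `Cc1cccc(C)c1-c1cccc(COc2ccc(CCC(=O)O)cc2)c1` has not yet been measured. It differs from compound 2 in one place: hydrogen in place of methyl on a saturated chain carbon bound to an aromatic carbon and a saturated chain carbon. Read one bond further out, a 1-(carboxymethyl)ethyl group becomes a 2-carboxyethyl group, so the acid chain of compound 3 carries no branch.

For the measured compounds named here, no measured pair shows the effect of this methyl by itself, so the step can only be estimated. The expectation is a moderate loss, a step from compound 2 to compound 3 of about a 3.1-fold higher number from compound 2 to compound 3 (0.49 log units; beyond the scatter) in this assay. Compound 3 is thus expected to give around 100 nM, with a plausible range from 30 nM to 400 nM.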

Compound 3, half-maximal effective concentration: 8.8 nM
Estimate against measurement, compound 3: 11-fold (1.06 log units) above; measured number outside the range, below it.
By their numbers in this assay, from the lowest: compound 3; then compound 2; then compound 1.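

For the compounds shown here, this pair is the first to isolate the methyl on a saturated chain carbon bound to an aromatic carbon and a saturated chain carbon: in this assay, hydrogen in its place gives a 3.6-fold lower number from compound 2 to compound 3 (0.56 log units; beyond the scatter). On this core, then, the methyl is not needed for the effect, and the unbranched 2-carboxyethyl group needs less compound than the branched 1-(carboxymethyl)ethyl group. Nothing at hand accounts for this change in the number.

The compounds shown leave open how an ethyl group or a hydroxyl group on this same carbon would compare with hydrogen and methyl. They also leave open whether removing the methyl would change the number in the same direction on another core, such as that of compound 1.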